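The source may report more compounds than this note shows. Statements on the series, on what has been measured and on what is new or still open speak of the compounds shown alone.

In a functional assay on MCF7 cells (Homo sapiens) for inhibition, read by MTT assay, with a stated time of 72 h (a higher number here means a weaker inhibitor, a lower number a stronger inhibitor), three compounds have been measured. Compound 1 `O=C1CS/C(=N\c2nc3cc(-c4ccc(Cl)cc4)sc3s2)N1` gives 12400 nM. Compound 3 `Cc1ccc(/C=C2/S/C(=N\c3nc4cc(-c5ccc(Cl)cc5)sc4s3)NC2=O)cc1` gives 3300 nM. Compound 2 `CN(C)c1ccc(/C=C2/S/C(=N\c3nc4cc(-c5ccc(Cl)cc5)sc4s3)NC2=O)cc1` gives > 50000 nM, which is a limit of the assay and not a number. Compound 2 therefore stands at the limit of > 50000 nM in this assay, at which 1 of the 3 values shown sits, and its true position on the scale is not known.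

Compound 4 `O=C1N/C(=N/c2nc3cc(-c4ccc(Cl)cc4)sc3s2)S/C1=C/c1ccc(Cl)cc1` has not yet been measured. It has chloro in place of dimethylamino on an aromatic carbon of a six-membered aromatic ring of carbon only, para to a large group, so that 4-(dimethylamino)phenyl becomes 4-chlorophenyl: chloro in place of dimethylamino on an aromatic carbon.

Among the compounds with values here, one measured step bears on this change. Putting methyl in the same place gives an at least 15-fold lower number from compound 2 to compound 3 (1.18 log units; beyond the scatter), so the removal of dimethylamino was large in that case. Within the data shown here, no measured step covers chloro itself, so this comparison is only a guide. A similarly large step towards a lower number, meaning stronger inhibition, is expected in this assay, with compound 3 at 3300 nM as the nearest reference. The expected change is an at least 11-fold lower number from compound 2 to compound 4 (1.04 log units; beyond the scatter). Compound 4 is estimated at 4500 nM, with an expected range of 1300 nM to 16000 nM.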

Compound 4, half-maximal inhibitory concentration: > 50000 nM
Compound 4 gave a limit, no number; the forecaster's own chance of this, stated with the estimate: 8%; middle value at least 11-fold (1.04 log units) from the limit.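

Compound 4 joins compound 2 at the top of the scale in this assay, and its value is a limit of the assay, not a number: the limit of > 50000 nM in this assay, at which 2 of the 4 values shown sit. Chloro in place of methyl on this aromatic carbon gives an at least 15-fold higher number from compound 3 to compound 4 (1.18 log units; beyond the scatter), so the earlier drop seen with methyl does not follow from losing dimethylamino alone, and the group that takes its place matters. Of the three groups shown at this place, only methyl gives a readable number, while the step between the two compounds at the limit cannot be read.

The compounds shown leave open whether the readable value of compound 3 is particular to methyl, or whether another small group on this aromatic carbon, such as ethyl, methoxy or fluoro, would also give a number. As far as these compounds go, how far compound 2 and compound 4 actually lie apart on the scale also remains unknown.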